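Swapping pyridin-3-yl for methylsulfanyl in compound 4

The source may hold more compounds than are shown below. What is called first, only, known or untested is meant among the compounds shown, and "the series" means these compounds.

In a functional assay on a cell-free system (plasma, Homo sapiens) for inhibition, with Plasma (Rattus norvegicus) as the target (on this read-out higher numbers stand for weaker inhibition and lower numbers for stronger inhibition), compound 2 (`Cc1c(OCc2cccnc2)ccc2c(N3CCNCC3)cc(=O)oc12`) gives 1420 nM, the lowest of the three numbers measured. Compound 3 (`O=c1cc(N2CCNCC2)c2cc(OCc3cccnc3)ccc2o1`) gives 36000 nM, and compound 1 (`O=c1cc(N2CCNCC2)c2ccccc2o1`) gives 250000 nM. Compound 4 (`CSCOc1ccc2c(N3CCNCC3)cc(=O)oc2c1C`) has not yet been measured in this assay. It differs from compound 2 by having methylsulfanyl in place of pyridin-3-yl on a saturated chain carbon bound to an oxygen on an aromatic ring.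

Within the data shown here, one measured step bears on this change. Putting (pyridin-3-yl)methoxy in place of hydrogen gave a 6.9-fold lower number from compound 1 to compound 3 (0.84 log units; beyond the scatter), a modest step beyond the scatter. Among the measured compounds shown here, that step covers the whole group, and no measured compound carries (methylsulfanyl)methoxy, so the data do not isolate pyridin-3-yl. Part of that gain is expected to be lost, which points to a modest move toward a higher number, no larger than that step. The expected change is a 2.8-fold higher number from compound 2 to compound 4 (0.45 log units; beyond the scatter). Compound 4 is estimated at 4000 nM, with an expected range of 1200 nM to 14000 nM.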

Compound 4, half-maximal inhibitory concentration: 3400 nM
Beside the measured number, compound 4's estimate is 1.2-fold (0.07 log units) above it; the measured number falls inside the stated range.
By their numbers in this assay, from the lowest: compound 2; then compound 4; then compound 3; then compound 1.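

In this assay, methylsulfanyl in place of pyridin-3-yl gave a 2.4-fold higher number from compound 2 to compound 4 (0.38 log units; beyond the scatter), a modest step beyond the scatter. Among these compounds, this is the first measured change that separates pyridin-3-yl from the rest of the (pyridin-3-yl)methoxy group, and it shows that, in this pair, the six-membered aromatic ring can give way to methylsulfanyl, which has no ring, at only a modest cost. No supporting measurement bears on why the number rises.

With only this one replacement at this place, the compounds shown leave open whether the rise follows the loss of the ring or the entry of sulfur. They also leave open how a phenyl ring, an amine or a longer alkyl chain on the same saturated chain carbon would compare with pyridin-3-yl and methylsulfanyl.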